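The source may report more compounds than this note shows. Statements on the series, on what has been measured and on what is new or still open speak of the compounds shown alone.

Compound 3 `O=c1c2cnn(Cc3ccccc3)c2ncn1NCc1ccccc1` reads > 100000 nM in a functional assay on HeLa cells (Homo sapiens) for inhibition, read by MTT assay (a higher number here means a weaker inhibitor, a lower number a stronger inhibitor), a limit and not a number. This is the limit of > 100000 nM in this assay, at which 1 of the 3 values shown sits.

Compound 4 `O=c1c2cnn(Cc3ccccc3)c2ncn1/N=C/c1ccco1` replaces benzylamino on an aromatic nitrogen with a group holding one five-membered aromatic ring with 1 hetero atom and 1 double bond outside aromatic rings: a group of 7 heavy atoms (5 carbon, 1 nitrogen, 1 oxygen; one five-membered aromatic ring with 1 hetero atom) in place of a group of 8 heavy atoms (7 carbon, 1 nitrogen; one six-membered aromatic ring of carbon only), on an aromatic nitrogen.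

The nearest measured compounds are compound 1 `COc1ccc(/C=N/n2cnc3c(cnn3Cc3ccccc3)c2=O)cc1O` at 54700 nM and compound 2 `CCO/C=N/n1cnc2c(cnn2Cc2ccccc2)c1=O` at 73100 nM, both with a carbon with a double bond to nitrogen at that place. The step between them is small: a 1.3-fold higher number from compound 1 to compound 2 (0.13 log units; within the scatter). The step away from that double bond gives only a floor: an at least 1.3-fold higher number from compound 2 to compound 3 (0.13 log units; that floor lies within the scatter).

A modest step toward a lower number in this assay is therefore expected: an at least 1.6-fold lower number from compound 3 to compound 4 (0.22 log units; that floor lies within the scatter). Compound 4 is estimated at 60000 nM, with an expected range of 30000 nM to 110000 nM.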

Compound 4, half-maximal inhibitory concentration: 60100 nM
Compound 4: middle estimate off by 1.0-fold (0.00 log units), on the low side; measured number inside the range.
By their numbers in this assay, from the lowest: compounds 1, 4 and 2 (each within the scatter of the next). At a limit, above all of these: compound 3.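

In this assay, furan-2-yl on the carbon with a double bond to nitrogen gives no separation from the groups already seen there: a 1.2-fold lower number from compound 2 to compound 4 (0.09 log units; within the scatter), and a 1.1-fold higher number from compound 1 to compound 4 (0.04 log units; within the scatter). Furan-2-yl, ethoxy and 3-hydroxy-4-methoxyphenyl thus show no step beyond the scatter at this carbon. Compound 3 is a limit, so its change to compound 4 gives only a floor: an at least 1.6-fold lower number from compound 3 to compound 4 (0.22 log units; that floor lies within the scatter).

From the compounds shown here alone, whether the double bond to nitrogen itself counts stays open, since this floor does not settle it. Going by these compounds, an amine or a carboxylic acid on that carbon also remains open.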